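Cyanoacrylamide series: the amide nitrogen substituent and cell growth

A few compounds are considered here, and "the series" means these few. Any claim that something is new, unique, unknown or untested is made for them only; others in the source may bear on it.

Measured so far in a functional assay on KB cells (Homo sapiens) for antiproliferative activity, read by MTT assay; on this read-out higher numbers stand for weaker inhibition and lower numbers for stronger inhibition:
- compound 1 `Cc1cccc(NC(=O)/C(C#N)=C/c2cc(O)c(O)c([N+](=O)[O-])c2)c1` gives 12.5 ug/mL
- compound 2 `N#C/C(=C\c1cc(O)c(O)c([N+](=O)[O-])c1)C(=O)Nc1ccccc1Cl` gives 37.4 ug/mL
- compound 3 `COc1c(O)ccc(/C=C(\C#N)C(=O)Nc2cccc(Cl)c2)c1[N+](=O)[O-]` gives a limit, > 100 ug/mL

Compound 2 stands highest of the two numbers in this assay; the nearest is compound 1, and the step of a 3.0-fold higher number from compound 1 to compound 2 (0.48 log units; beyond the scatter) lies beyond the scatter. Compound 3 in this assay reaches only the assay limit, which is not a number. One of the three values sits at the limit of > 100 ug/mL in this assay, at which 1 of the 3 values shown sits.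

Compound 4 `N#C/C(=C\c1cc(O)c(O)c([N+](=O)[O-])c1)C(N)=O` is not yet measured. The change from compound 2 is hydrogen in place of 2-chlorophenyl on an amide-type nitrogen. Among the measured compounds shown here, the only measured step that touches this position is a 3.0-fold higher number from compound 1 to compound 2 (0.48 log units; beyond the scatter), an exchange of one aryl group for another; no measured step removes the aryl group altogether, so the evidence for this change is indirect. Since that aryl swap already moved the number by a modest amount, the expectation for compound 4 is a further modest rise, a 1.7-fold higher number from compound 2 to compound 4 (0.24 log units; within the scatter), with the chance that the reading ends at the limit.

Compound 4 in this assay is therefore estimated at 65 ug/mL, expected between 18 ug/mL and 200 ug/mL.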

Compound 4, half-maximal inhibitory concentration: > 100 ug/mL
Compound 4: only a limit was reported (the forecaster's own chance of this, stated with the estimate: 30%); at least 1.5-fold (0.18 log units) between middle value and limit.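

In this assay, among the compounds shown here, the earlier compounds showed only one aryl group exchanged for another, a 3.0-fold higher number from compound 1 to compound 2 (0.48 log units; beyond the scatter), so they could not show whether an aryl group on the amide-type nitrogen is needed at all. Removing it altogether gives steps beyond the scatter from both aryl amides, an at least 2.6-fold higher number from compound 2 to compound 4 (0.42 log units; beyond the scatter) and an at least 8.0-fold higher number from compound 1 to compound 4 (0.90 log units; beyond the scatter), so within these compounds the 2-chlorophenyl and 3-methylphenyl amides both give stronger inhibition than the unsubstituted amide. Compound 4 gives > 100 ug/mL, which is a limit and not a number, so both steps give only a minimum size and the full loss stays unknown: the limit of > 100 ug/mL in this assay, at which 2 of the 4 values shown sit.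

The compounds shown do not tell whether the aromatic ring itself matters or whether any carbon group on this nitrogen would serve, a question that a methyl or benzyl group there would help to separate. Compound 3 differs from the other compounds in more than one place, so it gives no clean reading on this position.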